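The compounds below may be only part of what the source reports. "The series", "measured", "known", "first", "only" and "open" are said of these compounds alone.

Values in a physicochemical assay for solubility, read by HPLC, in phosphate buffer, measured as kinetic solubility, with a stated time of 1 h, at pH 7.4, tested at 250 uM; on this read-out higher numbers stand for higher solubility and lower numbers for lower solubility:
- compound 1 `CCCCCNC(=O)n1cc(-c2ccccc2)oc1=O`: < 1000 nM (a limit of the assay, not a number)
- compound 2 `CCOCCNC(=O)n1cc(-c2ccccc2)oc1=O`: 20000 nM
- compound 3 `O=C(NCCCCc1ccccc1)n1cc(-c2ccc(F)cc2)oc1=O`: < 1000 nM (a limit of the assay, not a number)

Compound 3 gives no number to work from and sits with compound 1 at the limit of < 1000 nM in this assay, at which 2 of the 3 values shown sit. Compound 4 `O=C(NCCCCc1ccccc1)n1cc(-c2cnccn2)oc1=O` keeps the rest of compound 3 and carries pyrazin-2-yl in place of 4-fluorophenyl on an aromatic carbon, next to the ring oxygen (pyrazin-2-yl in place of 4-fluorophenyl on an aromatic carbon).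

Among the compounds with values here, only one measured step offers guidance: an at least 20-fold higher number from compound 1 to compound 2 (1.30 log units; beyond the scatter). That step lies elsewhere, on a saturated chain, so it bears on this change only indirectly. There, as here, a group of carbon only among its heavy atoms, or carbon with fluorine, gives way to one with hetero atoms that accept hydrogen bonds. On this single precedent, a step to a higher number is expected in this assay, though smaller than the step to compound 2. The expected step is an at least 4.0-fold higher number from compound 3 to compound 4 (0.60 log units; beyond the scatter). With no number for compound 3 and no measured change at this aromatic carbon, the range stays wide, and a result at the limit remains possible. For compound 4 the estimate is 4000 nM, with an expected range of 1000 nM to 20000 nM.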

Compound 4, solubility: < 1000 nM
Compound 4 ended at the assay's limit (the forecaster's own chance of this, stated with the estimate: 30%); middle value at least 4.0-fold (0.60 log units) away from the limit.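

In this assay compound 3 and compound 4 both stand at a limit of the assay and not at a number, so no step can be read between them: the limit of < 1000 nM in this assay, at which 3 of the 4 values shown sit. The compounds shown leave open how far pyrazin-2-yl in place of 4-fluorophenyl moves the read-out, and whether any group at this aromatic carbon lifts a compound off the limit.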